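A few compounds are considered here, and "the series" means these few. Any claim that something is new, unique, unknown or untested is made for them only; others in the source may bear on it.

Measured compounds:
compound 1 `COc1cc(OC)c2c(=O)n(-c3cccc(C(=O)N4CCCCC4)c3)ccc2c1`: 18600 nM
compound 2 `COc1cc(OC)c2c(=O)n(-c3cccc(C(N)=O)c3)ccc2c1`: 31300 nM
compound 3 `COc1cc(O)c2c(=O)n(-c3cccc(C(=O)N4CCCCC4)c3)ccc2c1`: 14200 nM

Values come from a functional assay on A549 cells (Homo sapiens) for antiproliferative activity, read by MTT assay, with a stated time of 72 h; a higher number here means a weaker inhibitor, a lower number a stronger inhibitor. The cores of compound 1 and compound 3 differ by hydrogen in place of methyl on an oxygen on an aromatic ring, giving a 1.3-fold lower number from compound 1 to compound 3 (0.12 log units; within the scatter). Compound 2 differs from compound 1 by amino in place of piperidin-1-yl on a carbonyl carbon, and the step is a 1.7-fold higher number from compound 1 to compound 2 (0.23 log units; within the scatter). Compound 4 `COc1cc(O)c2c(=O)n(-c3cccc(C(N)=O)c3)ccc2c1` is not yet measured; it differs from compound 3 by amino in place of piperidin-1-yl on a carbonyl carbon, the same change as from compound 1 to compound 2, at the same place. Among the compounds with values here, compound 3 against compound 2 shows the two values differing beyond the scatter, though no single step covers that pair. For compound 4 the expected step is a 1.7-fold higher number from compound 3 to compound 4 (0.23 log units; within the scatter), beside a 1.7-fold higher number from compound 1 to compound 2 (0.23 log units; within the scatter); this rests on that earlier step and on compound 3 at 14200 nM. Compound 4 is thus estimated at 24000 nM, within 12000 nM to 50000 nM.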

Compound 4, half-maximal inhibitory concentration: 24800 nM
Estimate against measurement, compound 4: 1.0-fold (0.01 log units) below, within the range that was stated.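

In this assay, amino in place of piperidin-1-yl on the carbonyl carbon gives the same result on the second core as on the first, with a 1.7-fold higher number from compound 3 to compound 4 (0.24 log units; within the scatter) and no difference between the two steps beyond the scatter: the same change on two cores in this assay, a 1.7-fold higher number (0.23 log units; within the scatter) from compound 1 to compound 2 and a 1.7-fold higher number (0.24 log units; within the scatter) from compound 3 to compound 4, 1.0-fold (0.02 log units) apart, within the scatter of two such steps.
Hydrogen in place of methyl on the oxygen on the aromatic ring also carries over, with a 1.3-fold lower number from compound 2 to compound 4 (0.10 log units; within the scatter) and the same agreement: the same change on two cores in this assay, a 1.3-fold lower number (0.12 log units; within the scatter) from compound 1 to compound 3 and a 1.3-fold lower number (0.10 log units; within the scatter) from compound 2 to compound 4, 1.0-fold (0.02 log units) apart, within the scatter of two such steps.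
This shows that both changes transfer between these cores, but each rests on one pair of steps, all within the scatter, so it does not show that either change has a real effect on the read-out.

Going by these compounds, it remains open whether a carboxylic acid, a secondary amine or a longer chain on the carbonyl carbon would follow the same step. On these data alone, it also remains open whether any group there would move the number beyond the scatter.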